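From Methoxycarbonyl to Cyano in a Level Series

The compounds below may be only part of what the source reports. "The series", "measured", "known", "first", "only" and "open" are said of these compounds alone.

Compound 1 `COc1ccc(-c2cc3c(OC)cc(OC)cc3n(CCCC#N)c2=O)cc1`: 10000 nM
Compound 2 `COc1ccc(-c2cc3c(OC)cc(OC)cc3n(CC(=O)OCc3ccccc3)c2=O)cc1`: 10000 nM
Compound 3 `COC(=O)CCn1c(=O)c(-c2ccc(OC)cc2)cc2c(OC)cc(OC)cc21`: 10000 nM

These three compounds share one core and differ in the chain on the aromatic nitrogen. All were tested in a functional assay on A 172 cells (Homo sapiens) for cytotoxicity, read by colorimetric assay and MTT assay; on this read-out higher numbers stand for weaker inhibition and lower numbers for stronger inhibition. There compound 3 gives 10000 nM, level with compound 1 and compound 2 at the digits reported.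

Compound 4 `COc1ccc(-c2cc3c(OC)cc(OC)cc3n(CCC#N)c2=O)cc1` has not yet been measured. It departs from compound 3 at a single place: cyano in place of methoxycarbonyl on a saturated chain carbon, two bonds along the chain from an aromatic nitrogen.

The closest evidence is no change at the digits printed from compound 1 to compound 3 (within the scatter), since compound 1 also ends in a cyano group. Going by the values given here, the other two steps, no change at the digits printed from compound 1 to compound 2 (within the scatter) and no change at the digits printed from compound 2 to compound 3 (within the scatter), agree with it, and no measured compound goes against this level picture. The data therefore offer no direction, and no step beyond the scatter is expected in this assay. The expected change is no change at the digits printed from compound 3 to compound 4 (within the scatter). Compound 4 is estimated at 10000 nM, with an expected range from 3000 nM to 15000 nM.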

Compound 4, half-maximal inhibitory concentration: 10000 nM
Compound 4: the middle estimate sits on the measured number at the digits printed; the range from low to high includes it.
By their numbers in this assay, from the lowest: compounds 1, 2, 3 and 4 (each within the scatter of the next).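

In this assay, going by these compounds alone, the exchange of methoxycarbonyl, with 4 heavy atoms, for cyano, with 2 heavy atoms, at this place on the chain gives a direct comparison for the first time (no change at the digits printed from compound 3 to compound 4 (within the scatter)), and the read-out does not respond to it. Compound 4 also allows the two nitrile-bearing chains to be compared, with cyano in place of cyanomethyl (no change at the digits printed from compound 1 to compound 4 (within the scatter)), and it links the cyano series to the benzyl ester, with cyanomethyl in place of benzyloxycarbonyl (no change at the digits printed from compound 2 to compound 4 (within the scatter)), so neither of these changes separates the compounds either. No independent measurement is available to account for this uniform result.

On these data alone, with all four compounds level, the series does not show whether any group on this chain can move the read-out, and it remains open whether an amine, a carboxylic acid or a longer chain on the aromatic nitrogen would depart from this level. Also open, as far as these compounds go, is whether replacing the methoxy groups on the shared core would change the result in this assay.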